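The compounds below may be only part of what the source reports. "The series", "measured", "known", "first", "only" and "open" are said of these compounds alone.

Measured compounds in this series:
compound 1 `CCn1cnc2ncnc(N)c21` — > 100000 nM
compound 2 `CCC(C)n1cnc2ncnc(N)c21` — > 100000 nM

In an assay on CHO cells for displacement of a labelled ligand from adenosine receptor A1 (Homo sapiens) (on this read-out higher numbers stand for weaker inhibition and lower numbers for stronger inhibition), compound 1 gives > 100000 nM, which is a limit of the assay and not a number. Compound 2 gives > 100000 nM in this assay, again a limit. Among the compounds with values here, the one step that connects them, a step that the two limits leave unreadable from compound 1 to compound 2, ethyl in place of hydrogen on a saturated chain carbon bound to an aromatic nitrogen and a saturated chain carbon, therefore has no readable size: both ends sit where the assay stops reporting. Within the data shown here, the only evidence available is the limit of > 100000 nM in this assay, at which 2 of the 2 values shown sit, so nothing in the measured pair points in either direction.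

Compound 3 `CC(C)Cn1cnc2ncnc(N)c21` differs from compound 1 by isopropyl in place of methyl on a saturated chain carbon bound to an aromatic nitrogen; cut one bond further out, the same difference reads ethyl to isobutyl. Among the measured compounds shown here, with both neighbours at the limit and no step of known size to lean on, compound 3 is expected to remain at or near that limit, most likely reported as a limit once more. The estimate for compound 3 in this assay is 150000 nM, with a range of 50000 nM to 500000 nM. The implied step, a step that the limit leaves unreadable from compound 1 to compound 3, is expected to stay within the scatter.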

Compound 3, inhibition constant: > 100000 nM
Compound 3 ended at the assay's limit; the forecaster's own chance of this, stated with the estimate: 85%; the middle value is on the limit's open side.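

In this assay compound 3 gives > 100000 nM, a limit of the assay and not a number. Within the data shown here, compound 1 and compound 2 also stand at limits, so no step among the three compounds can be read. Still open, going by these compounds, is whether ethyl, sec-butyl and isobutyl on the aromatic nitrogen differ at all in this assay.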